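The source may hold more compounds than are shown below. What is called first, only, known or untested is meant among the compounds shown, and "the series" means these compounds.

Measured so far:
- compound 1 `COc1nc(NC2CC2)c2ncn([C@H]3C[C@H](N=[N+]=[N-])[C@@H](CO)O3)c2n1`: > 100000 nM
- compound 2 `[N-]=[N+]=N[C@H]1C[C@H](n2cnc3c(NC4CC4)nc(N)nc32)O[C@@H]1CO`: > 100000 nM

In an ADME assay on PBMC cells (Homo sapiens) for cytotoxicity, with a stated time of 5 days (a higher number here means a weaker inhibitor, a lower number a stronger inhibitor), compound 1 gives > 100000 nM, which is a limit and not a number. Compound 2 gives > 100000 nM, also a limit. Going by the values given here, the series so far is summed up by the limit of > 100000 nM in this assay, at which 2 of the 2 values shown sit.

Compound 3 `COc1nc(N)c2ncn([C@H]3C[C@H](N=[N+]=[N-])[C@@H](CO)O3)c2n1` differs from compound 1 by hydrogen in place of cyclopropyl on a nitrogen on an aromatic ring, or cyclopropylamino to amino. Among the compounds with values here, no measured step covers this change. Within the data shown here, the only one is a step that the two limits leave unreadable from compound 1 to compound 2, with amino in place of methoxy on an aromatic carbon, so it bears only indirectly and gives no size or direction. Nothing beyond the scatter is therefore expected in this assay, and compound 3 is expected to stay near the same limit. The expected step is a number no higher from compound 1 to compound 3 (the limit leaves the size open). For compound 3 the estimate is 100000 nM, with an expected range of 40000 nM to 200000 nM.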

Compound 3, half-maximal inhibitory concentration: 35000 nM
Compound 3: middle estimate off by 2.9-fold (0.46 log units), on the high side; measured number below the stated range.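

In this assay, going by these compounds alone, hydrogen in place of cyclopropyl on a nitrogen on an aromatic ring gives an at least 2.8-fold lower number from compound 1 to compound 3 (0.45 log units; beyond the scatter) and is the first step whose direction can be read. Compound 1 stands at > 100000 nM, which is a limit, so the step has a floor and no upper bound. Compound 3 is the only compound shown that comes off the limit: the limit of > 100000 nM in this assay, at which 2 of the 3 values shown sit.

A methyl or a longer chain such as n-propyl on that nitrogen would be needed to tell whether the cyclopropyl ring itself counts or any carbon group there keeps the number at the limit. Also open, on these data alone, is whether the same change holds with amino in place of methoxy on the aromatic carbon, since the step from compound 1 to compound 2 cannot be read.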